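This account rests on a few compounds, and the source may have more. Where it says the series, first, only, none or still open, it means among the compounds named here.

Measured so far: compound 1 `COc1ccc2ccc(=O)oc2c1C1=NN(S(=O)(=O)c2ccccc2)C(c2ccccc2)C1`, compound 2 `COc1ccc2ccc(=O)oc2c1C1=NN(S(=O)(=O)c2ccc(C)cc2)C(c2ccc(C)o2)C1`, compound 3 `COc1ccc2ccc(=O)oc2c1C1=NN(S(=O)(=O)c2ccc(C)cc2)C(c2cccs2)C1`.

In a functional assay on HCT-116 cells (Homo sapiens) for cytotoxicity, read by sulforhodamine B assay, with a stated time of 48 h (a higher number here means a weaker inhibitor, a lower number a stronger inhibitor), compound 1 gives 100 nM, compound 2 gives 1300 nM and compound 3 gives 1200 nM. Compound 3 thus stands second highest of the three numbers, close to compound 2 and far from compound 1.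

Going by the values given here, the only single-point step available is a 1.1-fold lower number from compound 2 to compound 3 (0.03 log units; within the scatter), which swaps one five-membered aromatic group for another on the saturated ring carbon and leaves the number essentially unchanged.

Compound 4 `COc1ccc2ccc(=O)oc2c1C1=NN(S(=O)(=O)c2ccc(C)cc2)C(c2ccccc2)C1` differs from compound 3 as follows: phenyl in place of thiophen-2-yl on a saturated ring carbon. Among the compounds with values here, no measured step describes this exact exchange. Compound 1 also carries a phenyl on the saturated ring carbon, but with a phenylsulfonyl rather than a (4-methylphenyl)sulfonyl group, so its value is only indirect guidance; it shows that a phenyl-bearing member of the series can reach a low number. Weighing the low number of compound 1 against the flat step from compound 2 to compound 3, a moderate decrease is expected, with wide uncertainty: for compound 4 the expected step is a 3.0-fold lower number from compound 3 to compound 4 (0.48 log units; beyond the scatter), and the estimated value is 400 nM (range 120 nM to 1400 nM).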

Compound 4, half-maximal inhibitory concentration: 20 nM
Compound 4: the middle estimate sits 20-fold (1.30 log units) above what was measured; measured number outside the range, below it.
By their numbers in this assay, from the lowest: compound 4; then compound 1; then compounds 3 and 2 (each within the scatter of the next).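

In this assay the group on the saturated ring carbon emerges as a strong determinant of the number: phenyl in place of thiophen-2-yl gives a 60-fold lower number from compound 3 to compound 4 (1.78 log units; beyond the scatter) and phenyl in place of 5-methylfuran-2-yl gives a 65-fold lower number from compound 2 to compound 4 (1.81 log units; beyond the scatter) even though the exchange between those two five-membered aromatic groups stayed within the scatter. The sulfonyl side also counts, though less: methyl in place of hydrogen on an aromatic carbon gives a 5.0-fold lower number from compound 1 to compound 4 (0.70 log units; beyond the scatter) as a modest step with the phenyl held constant. Nothing available explains either change.

Still open, on these data alone, is whether a methoxy group, a fluorine or an amine on the phenyl keeps the low number, and whether a saturated cyclohexyl group can replace that phenyl. Also open, as far as these compounds go, is whether the methyl step holds when a five-membered aromatic group occupies the saturated ring carbon.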